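Series notes: aryl swap on the shared core, HeLa inhibition

This account rests on a few compounds, and the source may have more. Where it says the series, first, only, none or still open, it means among the compounds named here.

In a functional assay on HeLa cells (Homo sapiens) for inhibition, read by CCK-8 assay, with a stated time of 48 h (on this read-out higher numbers stand for weaker inhibition and lower numbers for stronger inhibition), compound 2 `COc1cc(-c2ccnc3cc(-c4ccc5ccn(C)c5c4)nn23)cc(OC)c1OC` gives 187 nM, the lowest of the two numbers in hand. Compound 3 `COc1cc(-c2ccnc3cc(-c4cccc5c4ccn5CO)nn23)cc(OC)c1OC` gives 456 nM in this assay, a step up from compound 2 that lies beyond the scatter. Compound 1 `COc1cc(-c2ccnc3c(-c4ccc(C)cc4)cnn23)cc(OC)c1OC` is reported only as a limit in this assay, > 10000 nM; this is the limit of the assay, not a number, as noted in the limit of > 10000 nM in this assay, at which 1 of the 3 values shown sits.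

Compound 4 `C=Cc1ccc(-c2cc3nccc(-c4cc(OC)c(OC)c(OC)c4)n3n2)cc1` has not been measured in this assay. It differs from compound 2 by the change (4-vinylphenyl in place of 1-methyl-1H-indol-6-yl on an aromatic carbon). Among the measured compounds shown here, no step between two measured compounds here covers this kind of change, so the size of the step has to be estimated from the spread of the numbers alone: the two measured numbers sit within a moderate range of each other, and the fused indole group in compound 2 is replaced by a smaller single ring carrying a vinyl group.

The expectation is a loss of potency beyond the scatter, with the step of a 3.2-fold higher number from compound 2 to compound 4 (0.51 log units; beyond the scatter) taken as the working guess. Compound 4 is estimated at 600 nM in this assay, with a likely range from 150 nM to 3000 nM.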

Compound 4, half-maximal inhibitory concentration: 882 nM
Compound 4: the middle estimate sits 1.5-fold (0.17 log units) below what was measured, and the stated range covers the measured number.
By their numbers in this assay, from the lowest: compound 2; then compounds 3 and 4 (each within the scatter of the next). At a limit, above all of these: compound 1.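

In this assay, this position, on an aromatic carbon of the five-membered aromatic ring with 2 nitrogen, gives its first reading of a change of aryl group on the shared core: 4-vinylphenyl in place of 1-methyl-1H-indol-6-yl produces a 4.7-fold higher number from compound 2 to compound 4 (0.67 log units; beyond the scatter), so the change costs potency but does not abolish it. Compound 4 still gives a measured number rather than a limit, which shows that a single six-membered aromatic ring of carbon only, with no hydrogen-bond acceptor, is enough at this position for measurable inhibition. This single step changes the ring system and adds the vinyl double bond together, so it cannot assign the loss to either change alone.

Going by these compounds, how a 4-ethylphenyl or a 4-aminophenyl group would read at this position remains open, and such a comparison would help separate the part played by the vinyl group from that of the single ring. Nothing in the data in hand bears on the reason for the step from the indole group to the vinylphenyl group.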